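The source may report more compounds than this note shows. Statements on the series, on what has been measured and on what is new or still open speak of the compounds shown alone.

In a functional assay on MCF7 cells (Homo sapiens), read by MTT assay, with a stated time of 48 h (a lower number here means a stronger inhibitor, a higher number a weaker inhibitor), compound 3 (`CCOC(=O)CN(C)C(=O)c1ccc(C(CC)(CC)c2ccc(OCC(O)C(C)(C)C)c(C)c2)n1CC`) gives 9200 nM, the highest of the three numbers, against compound 1 (`CCn1c(C(=O)NCCCN(C)C)ccc1C(CC)(CC)c1ccc(OCC(=O)C(C)(C)C)c(C)c1`) at 340 nM and compound 2 (`CCn1c(C(=O)NCCN)ccc1C(CC)(CC)c1ccc(OCC(=O)C(C)(C)C)c(C)c1`) at 75 nM. The change to compound 4 (`CCn1c(C(=O)NCC(OC)OC)ccc1C(CC)(CC)c1ccc(OCC(O)C(C)(C)C)c(C)c1`) is (2,2-dimethoxyethyl)amino in place of ((ethoxycarbonyl)methyl)(methyl)amino on a carbonyl carbon. Going by the values given here, the only measured step, a 4.5-fold lower number from compound 1 to compound 2 (0.66 log units; beyond the scatter), is modest and bears on this only loosely. Neither of its groups appears in the present change, and compounds 1 and 2 also differ from compound 3 elsewhere in the structure. No step beyond the scatter is therefore expected in this assay. The estimated step is a 1.7-fold lower number from compound 3 to compound 4 (0.22 log units; within the scatter). The estimate for compound 4 is 5500 nM, with an expected range of 1500 nM to 20000 nM.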

Compound 4, half-maximal inhibitory concentration: > 50000 nM
Compound 4: only a limit was reported (the forecaster's own chance of this, stated with the estimate: 15%); middle value at least 9.0-fold (0.95 log units) from the limit.
By their numbers in this assay, from the lowest: compound 2; then compound 1; then compound 3. At a limit, above all of these: compound 4.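

In this assay compound 4 is reported only as a limit, not as a number: the limit of > 50000 nM in this assay, at which 1 of the 4 values shown sits.
On a carbonyl carbon, (2,2-dimethoxyethyl)amino in place of ((ethoxycarbonyl)methyl)(methyl)amino gives an at least 5.4-fold higher number from compound 3 to compound 4 (0.73 log units; beyond the scatter), so this position responds to an exchange of two groups that carry no net charge.
The earlier step among the amine-bearing chains, a 4.5-fold lower number from compound 1 to compound 2 (0.66 log units; beyond the scatter), did not show this.

On these data alone, the full size of the new step stays open, as only its lower bound is known.
Also open, as far as these compounds go, is how a primary amine or a carboxylic acid in place of the ethyl ester would read on the core of compound 3.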